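A few compounds are considered here, and "the series" means these few. Any claim that something is new, unique, unknown or untested is made for them only; others in the source may bear on it.

Compound 2, `COc1cc(-c2nn(-c3cccc(NC(=O)c4ccc(Cl)c(C(F)(F)F)c4)c3)cc2-c2ccncc2)ccc1Cl`, is one of the two compounds already measured in a functional assay on SF-539 cells (Homo sapiens) for inhibition, read by sulforhodamine B assay, with a stated time of 48 h; a lower number here means that less compound is tolerated, a higher number that more compound is tolerated. In this assay compound 2 gives > 32500 nM, which is a limit of the assay rather than a number. Compound 1, `COc1cc(-c2nn(-c3cccc(NC(=O)Nc4ccc(Cl)c(Cl)c4)c3)cc2-c2ccncc2)ccc1Cl`, is the other measured compound; in this assay compound 1 also gives only a limit, > 50000 nM. Within the data shown here, the one step between them, a step that the two limits leave unreadable from compound 1 to compound 2, cannot be read, since the limit of > 50000 nM in this assay, at which 1 of the 2 values shown sits, and the limit of > 32500 nM in this assay, at which 1 of the 2 values shown sits, are the limits at which its two ends sit. Compound 3, `COc1cc(-c2nn(-c3cccc(NC(=O)Nc4ccc(Cl)c(C(F)(F)F)c4)c3)cc2-c2ccncc2)ccc1Cl`, is the compound not yet measured; it differs from compound 2 by (4-chloro-3-(trifluoromethyl)phenyl)amino in place of 4-chloro-3-(trifluoromethyl)phenyl on a carbonyl carbon. Compound 1 also carries an amino group on the carbonyl carbon and sits at a limit, so the step that the limit leaves unreadable from compound 2 to compound 3 is expected to be no change that could be read beyond the scatter. Compound 3 is therefore estimated to give 50000 nM in this assay, with a range from 15000 nM to 100000 nM, most likely again reported only as a limit.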

Compound 3, concentration lethal to 50% of the cells: 17500 nM
Compound 3: middle estimate off by 2.9-fold (0.46 log units), on the high side; measured number inside the range.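

In this assay, compound 3 is the only one of the three compounds shown that gives a real number rather than a limit, so this part of the molecule can now move the read-out into a range that can be measured. Placing an amino group on the carbonyl carbon, with the 4-chloro-3-(trifluoromethyl)phenyl ring kept, gives an at least 1.8-fold lower number from compound 2 to compound 3 (0.26 log units; that floor lies within the scatter), so this change alone cannot be told apart from ordinary variation between repeats. The clearer result is on the ring, where keeping that amino group and changing only the ring substituent gives an at least 2.8-fold lower number from compound 1 to compound 3 (0.45 log units; beyond the scatter), which means that less compound is tolerated with trifluoromethyl than with chloro, while the step between compound 1 and compound 2 cannot be read.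

Both readable steps are only minimum sizes, so their true sizes stay open, as does any explanation for them. On these data alone, it is also open how the number would respond to a nitrile or a methyl group in place of the trifluoromethyl, or to a longer chain between the carbonyl carbon and the ring.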